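From chloro to nitro on the aromatic ring

A few compounds are considered here, and "the series" means these few. Any claim that something is new, unique, unknown or untested is made for them only; others in the source may bear on it.

In an ADME assay on Vero cells (Chlorocebus sabaeus) for cytotoxicity, read by resazurin assay, with a stated time of 72 h (a lower number here means a stronger inhibitor, a higher number a weaker inhibitor), compound 3 (`O=C(CCN1CCN(c2ccc(Cl)cc2)CC1)c1ccc(Br)cc1`) gives 52100 nM. Compound 2 (`O=C(CCN1CCN(c2ccc(F)cc2)CC1)c1ccc(Br)cc1`) gives 99500 nM, and the comparison shows a 1.9-fold lower number from compound 2 to compound 3 (0.28 log units; within the scatter). Compound 1 (`Cc1ccc(C(=O)CCN2CCN(c3ccc([N+](=O)[O-])cc3)CC2)cc1`) gives 235000 nM, a higher number than compound 3 by more than the scatter.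

Compound 4 (`O=C(CCN1CCN(c2ccc([N+](=O)[O-])cc2)CC1)c1ccc(Br)cc1`) has nitro in place of chloro on an aromatic carbon, para to a large group, relative to compound 3: nitro in place of chloro on an aromatic carbon. Within the data shown here, the only measured step in one place, from fluoro to chloro, stays within the scatter and does not involve nitro, so it offers little guidance. Compound 1, at 235000 nM, already carries the nitro group but differs from compound 4 elsewhere in the structure, so it is only a loose guide. It nevertheless points towards a moderately higher number in this assay. The expected change is a 2.1-fold higher number from compound 3 to compound 4 (0.32 log units; beyond the scatter). For compound 4 the estimated value is 110000 nM, with an expected range from 45000 nM to 240000 nM.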

Compound 4, half-maximal inhibitory concentration: 79800 nM
Estimate against measurement, compound 4: 1.4-fold (0.14 log units) above, and the stated range covers the measured number.
By their numbers in this assay, from the lowest: compounds 3, 4 and 2 (each within the scatter of the next); then compound 1.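

In this assay nitro in place of chloro on this aromatic carbon (a 1.5-fold higher number from compound 3 to compound 4 (0.19 log units; within the scatter)) and nitro in place of fluoro (a 1.2-fold lower number from compound 2 to compound 4 (0.10 log units; within the scatter)) both stay within the scatter, so the numbers do not tell fluoro, chloro and nitro apart at this position, para to a large group. Among these compounds, the step at the other place in the structure, bromo in place of methyl on an aromatic carbon with nitro held fixed (a 2.9-fold lower number from compound 1 to compound 4 (0.47 log units; beyond the scatter)), is the only new step beyond the scatter, and it is a modest one. No supporting evidence is available to explain either result.

From the compounds shown here alone, it remains open whether an amine or a carboxylic acid at this position would also stay within the scatter. Going by these compounds, it is also open whether the step from methyl to bromo would keep its size with chloro or fluoro in place of nitro.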